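Sulfamoyl in place of fluoro on compound 3

The compounds below may be only part of what the source reports. "The series", "measured", "known", "first", "only" and "open" are said of these compounds alone.

Values in a functional assay on MCF7 cells (Homo sapiens) for antiproliferative activity, read by sulforhodamine B assay, with a stated time of 72 h (a lower number here means a stronger inhibitor, a higher number a weaker inhibitor), so far
compound 1 `C(=C/c1ccccc1)\C(=N\Nc1nncc2ccccc12)c1ccccc1` gives 2.2 nM
compound 2 `Clc1ccc(C(/C=C/c2ccccc2)=N\Nc2nncc3ccccc23)cc1` gives 3.6 nM
compound 3 `Fc1ccc(Nc2nncc3ccccc23)cc1` gives 3.5 nM

Compound 3 at 3.5 nM lies within the scatter of both other compounds. Compound 4 `NS(=O)(=O)c1ccc(Nc2nncc3ccccc23)cc1` carries sulfamoyl in place of fluoro on an aromatic carbon, para to a large group, with sulfamoyl in place of fluoro on an aromatic carbon as the counted difference. For the measured compounds named here, only one measured step exists, a 1.6-fold higher number from compound 1 to compound 2 (0.21 log units; within the scatter) as a chloro in place of hydrogen, and this different exchange on a different parent gives weak guidance. A small rise is expected, with a 1.4-fold higher number from compound 3 to compound 4 (0.15 log units; within the scatter) as the estimated step and its direction uncertain. In this assay compound 4 is estimated at 5 nM with values from 1.5 nM to 20 nM as the expected range.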

Compound 4, half-maximal inhibitory concentration: 37 nM
Compound 4: the middle estimate sits 7.4-fold (0.87 log units) below what was measured; measured number outside the range, above it.
By their numbers in this assay, from the lowest: compounds 1, 3 and 2 (each within the scatter of the next); then compound 4.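

In this assay, for the compounds shown here, the place para to a large group does not accept every exchange: sulfamoyl in place of fluoro gives (an 11-fold higher number from compound 3 to compound 4 (1.02 log units; beyond the scatter)), the first step beyond the scatter. The earlier chloro step, made on a different parent, stayed within the scatter and gave no sign of this. Nothing measured here accounts for the rise.

Two groups at one place give no trend. A carboxylic acid, an amine or a methyl sulfone there would show whether the rise is specific to sulfamoyl.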